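The compounds below may be only part of what the source reports. "The series", "measured", "known", "first", "only" and "open" are said of these compounds alone.

Compound 1 `O=C(O)Cc1sc(COc2ccc(Cl)cc2)nc1-c1ccc(Cl)cc1` — 370 nM
Compound 2 `CCC(c1ccccc1)c1nc(-c2ccc(Cl)cc2)c(CC(=O)O)s1` — a limit, > 100000 nM
Compound 3 `O=C(O)Cc1sc(C(c2ccc(F)cc2)c2ccc(F)cc2)nc1-c1cc(F)cc(F)c1` — 340 nM

In an in vitro functional assay on HEK285-7 cells for antagonist activity at prostaglandin D2 receptor 2 (Homo sapiens), read by BRET and beta-arrestin recruitment (on this read-out lower numbers stand for stronger inhibition and higher numbers for weaker inhibition), compound 1 gives 370 nM. For compound 2 the result is a limit of this assay rather than a number, > 100000 nM; this is the limit of > 100000 nM in this assay, at which 1 of the 3 values shown sits. Compound 3 gives 340 nM in this assay and so holds the lowest of the two numbers shown, yet its nearest neighbour, compound 1, sits within the usual scatter of the assay, so the two cannot be told apart.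

Compound 4 `O=C(O)Cc1sc(C(c2ccc(F)cc2)c2ccc(F)cc2)nc1-c1ccnc(N2CCCC2)c1` has not yet been measured in this assay. It differs from compound 3 in a single place: 2-(pyrrolidin-1-yl)pyridin-4-yl in place of 3,5-difluorophenyl on an aromatic carbon. Among the measured compounds shown here, no measured pair in this set varies that part of the shared core, so there is no measured step to lean on, and the effect of the change has to be guessed.

Since compound 3 gives 340 nM, and the change leaves the rest of the shared core untouched, a modest step in this assay is expected, most likely toward a somewhat higher number, though a value within the scatter would not surprise. Compound 4 is therefore estimated to give about 600 nM in this assay, with a range from 120 nM to 3000 nM. This corresponds to an expected step of a 1.8-fold higher number from compound 3 to compound 4 (0.25 log units; within the scatter).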

Compound 4, half-maximal inhibitory concentration: > 100000 nM
Compound 4 gave a limit, no number; the forecaster's own chance of this, stated with the estimate: 10%; middle value at least 160-fold (2.22 log units) away from the limit.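

The change of 3,5-difluorophenyl to 2-(pyrrolidin-1-yl)pyridin-4-yl, on the aromatic carbon next to the ring nitrogen, gives in this assay an at least 290-fold higher number from compound 3 to compound 4 (2.46 log units; beyond the scatter), the only measured step at this position among the compounds shown. Compounds 1, 2 and 3 differ from one another in more than one place, so they could not show that this position alone can carry a change of such size, and the position is clearly not indifferent to what it holds. The value of compound 4 is a limit of the assay and not a number, so the true size of the step stays unknown, and compound 4 now sits at a limit already seen in this set: the limit of > 100000 nM in this assay, at which 2 of the 4 values shown sit.

The single change removes the fluorine atoms, brings in a ring nitrogen and adds a pyrrolidine ring all at once, and the compounds shown do not tell which of these accounts for the result. A pyridin-4-yl group without the pyrrolidine, or an unsubstituted phenyl at this place, would separate these parts, and no compound shown carries either.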